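Swapping the benzylamine of compound 2 for a neopentyl amine

A few compounds are considered here, and "the series" means these few. Any claim that something is new, unique, unknown or untested is made for them only; others in the source may bear on it.

Compound 2 `OC1(CNCc2ccccc2)CCN(CCCc2c[nH]c3ccc(-n4cnnc4)cc23)CC1` shows the highest of the two numbers recorded in an assay on CHO cells with 5-hydroxytryptamine receptor 1B (Homo sapiens) as the target (on this read-out higher numbers stand for weaker inhibition and lower numbers for stronger inhibition), with compound 2 giving 47 nM; its nearest neighbour, compound 1 `CN(CC1CC1)CC1(O)CCN(CCCc2c[nH]c3ccc(-n4cnnc4)cc23)CC1`, gives 27 nM. Among the compounds with values here, the one measured step, a 1.7-fold higher number from compound 1 to compound 2 (0.24 log units; within the scatter), bears directly on the next change. Compound 3 `CN(CC(C)(C)C)CC1(O)CCN(CCCc2c[nH]c3ccc(-n4cnnc4)cc23)CC1` differs from compound 2 by methyl(neopentyl)amino in place of benzylamino on a saturated chain carbon bound to a saturated ring carbon. Since compound 1 and compound 2 sit within the scatter of each other, the step to compound 3 is expected to stay near the scatter as well, about a 1.6-fold lower number from compound 2 to compound 3 (0.19 log units; within the scatter). Compound 3 is therefore estimated at 30 nM, within a range of 12 nM to 75 nM.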

Compound 3, half-maximal inhibitory concentration: 61 nM
Compound 3: the middle estimate sits 2.0-fold (0.31 log units) below what was measured; low and high end bracket the measured number.
By their numbers in this assay, from the lowest: compounds 1, 2 and 3 (each within the scatter of the next, the first and the last beyond it).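

On the saturated chain carbon bound to a saturated ring carbon, methyl(neopentyl)amino in place of benzylamino gives (a 1.3-fold higher number from compound 2 to compound 3 (0.11 log units; within the scatter)) in this assay, so the six-membered aromatic ring of carbon only is not required for a number of this size among these compounds. Tert-butyl in place of cyclopropyl on a saturated chain carbon bound to an amine nitrogen gives (a 2.3-fold higher number from compound 1 to compound 3 (0.35 log units; beyond the scatter)), the only step here beyond the scatter. Nothing at hand accounts for either step. The compounds shown leave open how an amide or a phenethylamino group would read at this position.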